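Series notes: amide replacement on the shared core

A few compounds are considered here, and "the series" means these few. Any claim that something is new, unique, unknown or untested is made for them only; others in the source may bear on it.

Measured compounds:
Compound 1, `O=C(c1ccc(C(F)(F)F)cc1)N1CCC(NS(=O)(=O)c2cc(S(=O)(=O)c3ccccc3)ccc2C(F)(F)F)CC1`, gives 970 nM in an assay on U2OS cells for inhibition of secreted frizzled-related protein 1 (Homo sapiens), read by a luciferase reporter, with a stated time of 18 h; on this read-out lower numbers stand for an effect already at smaller amounts and higher numbers for an effect only at larger amounts of compound.
Compound 2, `CC(C)(O)CCN1CCC(NS(=O)(=O)c2cc(S(=O)(=O)c3ccccc3)ccc2C(F)(F)F)CC1`, gives 630 nM in this assay.

Within the data shown here, compound 1 has the highest of the two numbers so far; its nearest neighbour is compound 2, and the step of a 1.5-fold lower number from compound 1 to compound 2 (0.19 log units; within the scatter) does not separate the two. The unmeasured compound 3, `CC(C)(C)OC(=O)N1CCC[C@H]1C(=O)N1CCC(NS(=O)(=O)c2cc(S(=O)(=O)c3ccccc3)ccc2C(F)(F)F)CC1`, keeps the whole sulfonamide part of compound 1 and changes only the group on the carbonyl carbon: 1-(tert-butoxycarbonyl)pyrrolidin-2-yl in place of 4-(trifluoromethyl)phenyl on a carbonyl carbon. Among the measured compounds shown here, no measured step changes this very group, so the step from compound 1 to compound 2 is the only point of comparison. It exchanges the entire (4-(trifluoromethyl)phenyl)carbonyl on the amine nitrogen in the ring, a larger alteration at the same end of the molecule, and it still moved the number only a little. On that basis the expectation for compound 3 in this assay is a step of about a 1.0-fold higher number from compound 1 to compound 3 (0.01 log units; within the scatter), that is, nothing beyond the usual scatter. Compound 3 is therefore estimated at 1000 nM, with a range from 400 nM to 2500 nM.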

Compound 3, half-maximal effective concentration: 60 nM
Compound 3: middle estimate off by 17-fold (1.22 log units), on the high side; the whole stated range lies above it.
By their numbers in this assay, from the lowest: compound 3; then compounds 2 and 1 (each within the scatter of the next).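

Working notes on the carbonyl position: the group on the carbonyl carbon strongly affects the number in this assay. Placing 1-(tert-butoxycarbonyl)pyrrolidin-2-yl there in place of 4-(trifluoromethyl)phenyl gives a 16-fold lower number from compound 1 to compound 3 (1.21 log units; beyond the scatter), so this position responds far more than the earlier comparison suggested, where a 1.5-fold lower number from compound 1 to compound 2 (0.19 log units; within the scatter) did not separate the two compounds. The change replaces an aromatic carbon ring with a non-aromatic five-membered ring and adds two hydrogen-bond acceptors and a defined stereocentre in a single step, and no information at hand explains the shift or assigns it to any one of these features.

Still open, as far as these compounds go, is whether the lower number in compound 3 depends on the tert-butoxycarbonyl group or on the pyrrolidine ring itself, a question that a free ring amine or an acetyl group on the ring nitrogen would help to settle. From the compounds shown here alone, the role of the defined stereocentre also remains open, as does the effect of an open-chain amine or a carboxylic acid on the same carbonyl carbon.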